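This account rests on a few compounds, and the source may have more. Where it says the series, first, only, none or still open, it means among the compounds named here.

Working notes on the series.

Compound 1 `CCC(=O)Nc1ccc(-c2nc3cc(C(F)(F)F)ccc3[nH]2)cc1` carries a propanamide on the pendant aryl ring and a trifluoromethyl on the shared core. In an ADME assay on BHK cells (Mesocricetus auratus) for cytotoxicity, read by MTT assay, with a stated time of 96 h (on this read-out lower numbers stand for higher toxicity in this test and higher numbers for lower toxicity in this test), compound 1 gives 100000 nM. Compound 3 `CCC(=O)Nc1ccc(-c2nc3ccccc3[nH]2)cc1` differs from compound 1 by hydrogen in place of trifluoromethyl on an aromatic carbon. In this assay compound 3 gives only a limit, >= 100000 nM, and not a number. The step of a number no lower from compound 1 to compound 3 (the limit leaves the size open) therefore cannot be sized, because the limit of >= 100000 nM in this assay, at which 1 of the 3 values shown sits, caps what the read-out reports.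

Compound 2 `O=[N+]([O-])c1ccc(-c2nc3cc(C(F)(F)F)ccc3[nH]2)c([N+](=O)[O-])c1` carries two nitro groups on the pendant aryl ring and keeps the trifluoromethyl on the core. In this assay compound 2 gives 8000 nM, the lowest of the two numbers at hand and well apart from compound 1. How compound 2 and compound 1 differ is not broken down here.

Compound 4 `O=[N+]([O-])c1ccc(-c2nc3ccccc3[nH]2)c([N+](=O)[O-])c1` is not yet measured. It differs from compound 2 by hydrogen in place of trifluoromethyl on an aromatic carbon, the same change as that from compound 1 to compound 3, on the same place. Because a number no lower from compound 1 to compound 3 (the limit leaves the size open) shows no fall in the number, the corresponding step of a 1.9-fold higher number from compound 2 to compound 4 (0.27 log units; within the scatter) is expected to be of the same direction, with its size left open by the limit on compound 3. Compound 4 is estimated to give 15000 nM in this assay, within 6000 nM to 60000 nM.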

Compound 4, half-maximal cytotoxic concentration: > 100000 nM
Compound 4 was reported as a limit (the forecaster's own chance of this, stated with the estimate: 10%); middle value at least 6.6-fold (0.82 log units) away from the limit.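

In this assay, hydrogen in place of trifluoromethyl on an aromatic carbon, on the core that carries two nitro groups on the pendant aryl ring, gives an at least 12-fold higher number from compound 2 to compound 4 (1.09 log units; beyond the scatter). On these data alone, compound 4 gives > 100000 nM, which is a limit and not a number, so the true size of this step stays open. Carried between the two cores, the change shows no fall in the number on either, which is as far as the comparison goes: the step on the propanamide pair cannot be read, so these two pairs do not show that the change has the same size on both cores, nor that it has a different one: the same change on two cores in this assay, a number no lower (the limit leaves the size open) from compound 1 to compound 3 and an at least 12-fold higher number (1.09 log units; beyond the scatter) from compound 2 to compound 4; the limit leaves it open whether they differ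

The compounds shown leave open how the change behaves when the pendant aryl ring carries neither propanamide nor nitro groups, for instance an amine, a carboxylic acid or a longer chain in their place. They also leave open whether a group other than hydrogen in the place of trifluoromethyl, such as chlorine or methyl, would give a step in the same direction on either core.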